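Swapping bromo for ethyl on a benzamide tail

The compounds below may be only part of what the source reports. "The series", "measured", "known", "first", "only" and "open" are said of these compounds alone.

Compound 2 `O=C(Nc1cccc(-c2oc3cc(-c4ccc(F)cc4)ccc3c(=O)c2O)c1)c1ccc(Br)cc1` belongs to a small pair sharing one core and differing only in the acyl group on the amide nitrogen. In a functional assay on A549 cells (Homo sapiens) for antiproliferative activity, read by CCK-8 assay, with a stated time of 72 h (on this read-out higher numbers stand for weaker inhibition and lower numbers for stronger inhibition), compound 2 gives 13500 nM, the higher of the two numbers shown, meaning the weaker of the pair. Among the measured compounds shown here, its partner, compound 1 `O=C(Nc1cccc(-c2oc3cc(-c4ccc(F)cc4)ccc3c(=O)c2O)c1)c1ccccc1F`, gives 4410 nM in this assay, and the step of a 3.1-fold higher number from compound 1 to compound 2 (0.49 log units; beyond the scatter) is the only measured change available.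

Compound 3 `CCc1ccc(C(=O)Nc2cccc(-c3oc4cc(-c5ccc(F)cc5)ccc4c(=O)c3O)c2)cc1` is the next compound to be measured. It differs from compound 2 by ethyl in place of bromo on an aromatic carbon, so the 4-bromophenyl becomes a 4-ethylphenyl on the same carbonyl carbon. For the measured compounds named here, no measured step addresses this exact exchange: the step from compound 1 to compound 2 replaced one aryl ring by another with a different substitution, which says little about swapping a halogen for a short chain at the same position. With nothing pointing clearly either way, the expected step of a 1.2-fold lower number from compound 2 to compound 3 (0.09 log units; within the scatter) is small, within or only just beyond the scatter. Compound 3 is therefore estimated at 11000 nM in this assay, with a plausible range from 4000 nM to 30000 nM.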

Compound 3, half-maximal inhibitory concentration: 18500 nM
Beside the measured number, compound 3's estimate is 1.7-fold (0.23 log units) below it, within the range that was stated.
By their numbers in this assay, from the lowest: compound 1; then compounds 2 and 3 (each within the scatter of the next).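

Exchanging bromo for ethyl gives a 1.4-fold higher number from compound 2 to compound 3 (0.14 log units; within the scatter) in this assay, so at this place on the ring the two groups cannot be told apart, even though one is a single halogen atom and the other a short carbon chain. Among the compounds shown here, compound 3 also gives a 4.2-fold higher number from compound 1 to compound 3 (0.62 log units; beyond the scatter), a modest gap that puts both the 4-bromophenyl and the 4-ethylphenyl compounds at clearly higher numbers than compound 1, the only compound here with a 2-fluorophenyl group. No supporting measurement is available to explain why the numbers fall this way.

The gap to compound 1 cannot yet be assigned to a single feature, since its ring differs from the other two in both the substituent and where it sits; a 2-bromophenyl or 2-ethylphenyl partner would separate those two changes. As far as these compounds go, it also remains open whether this position stays as flat with a group of a different kind, such as an amine, a carboxylic acid or a longer chain like hexyl, in place of the bromo or ethyl.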